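A few compounds are considered here, and "the series" means these few. Any claim that something is new, unique, unknown or untested is made for them only; others in the source may bear on it.

Measured compounds: compound 1 `O=C(c1cccc(Cl)c1)N1CCn2nc(-c3ccc(F)cn3)cc2C1`, compound 2 `Cc1cccc(C(=O)N2CCn3nc(-c4ccc(F)cn4)cc3C2)c1`, compound 3 `O=C(c1cccc(C(F)(F)F)c1)N1CCn2nc(-c3ccc(F)cn3)cc2C1`. In a functional assay on HEK293 cells for negative allosteric modulation of metabotropic glutamate receptor 5 (Homo sapiens), read by calcium flux, with a stated time of 20 min (on this read-out lower numbers stand for stronger inhibition and higher numbers for weaker inhibition), compound 1 gives 150 nM, compound 2 gives 150 nM, and compound 3 gives 383 nM.

Compound 2 stands level with compound 1 at the digits shown, the two together giving the lowest numbers of the three; compound 3 lies furthest away, with a 2.6-fold higher number from compound 2 to compound 3 (0.41 log units; beyond the scatter). Compound 4 `Cc1cc(F)cc(C(=O)N2CCn3nc(-c4ccc(F)cn4)cc3C2)c1` differs from compound 2 by fluoro in place of hydrogen on an aromatic carbon, the fluoro sitting meta to the methyl group. Among the compounds with values here, no measured step swaps a hydrogen for fluoro. The steps that exist exchange the single ring substituent: no change at the digits printed from compound 1 to compound 2 (within the scatter) and a 2.6-fold higher number from compound 2 to compound 3 (0.41 log units; beyond the scatter), both modest at most. The added fluoro is therefore expected to shift this assay little, probably within the scatter. Compound 4 is estimated at 150 nM, between 60 nM and 400 nM. This corresponds to an expected no change at the digits printed from compound 2 to compound 4 (within the scatter).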

Compound 4, half-maximal inhibitory concentration: 197 nM
Beside the measured number, compound 4's estimate is 1.3-fold (0.12 log units) below it, and the stated range covers the measured number.
By their numbers in this assay, from the lowest: compounds 1, 2, 4 and 3 (each within the scatter of the next, the first and the last beyond it).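

In this assay, fluoro in place of hydrogen on the aromatic ring, meta to the methyl group, gives a 1.3-fold higher number from compound 2 to compound 4 (0.12 log units; within the scatter) and so shows that this position accepts a fluoro without a change beyond the scatter. The exchange of 3-chlorophenyl for 3-fluoro-5-methylphenyl gives a 1.3-fold higher number from compound 1 to compound 4 (0.12 log units; within the scatter) and so shows that this ring can carry the added fluoro and still read alongside compound 1. Nothing shown explains these results. From the compounds shown here alone, whether a methoxy group or an amine at this position would give a similar number remains open.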